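A few compounds are considered here, and "the series" means these few. Any claim that something is new, unique, unknown or untested is made for them only; others in the source may bear on it.

Measured compounds:
compound 1, `CCOC(=O)c1c(O)c2cccnc2n(-c2ccccc2)c1=O`, 23.5%
compound 2, `O=C(Nc1ccc(Cl)cc1)c1c(O)c2cccnc2n(-c2ccccc2)c1=O`, 11.6%

Among the measured compounds shown here, in a functional assay on the whole organism for inhibition, with Rattus norvegicus as the target, read by paw edema, at a dose of 100 mg/kg by the oral route (a lower number here means less inhibition, a higher number more inhibition at the dose given (going by the name of the read-out)), compound 2 stands lowest of the two numbers; the only other number, that of compound 1, stands higher, and the single measured step is a number 11.9 percentage points lower from compound 1 to compound 2 (beyond the scatter). Compound 3, `COc1ccccc1NC(=O)c1c(O)c2cccnc2n(-c2ccccc2)c1=O`, has not been measured. It differs from compound 2 by 2-methoxyphenyl in place of 4-chlorophenyl on an amide-type nitrogen. For the measured compounds named here, the measured step exchanges an ethoxy for an arylamino group on the carbonyl carbon and does not cover a swap of one aryl group for another on the amide-type nitrogen; no step shows such a change. The expected step of a number 3.4 percentage points higher from compound 2 to compound 3 (within the scatter) is therefore small, without a clear direction beyond the scatter. Compound 3 is estimated at 15%, within 0% to 35%.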

Compound 3, a percentage reported as inhibition, in the whole organism at one dose (the size of the read-out at that dose, not a potency): 8.1%
The estimate for compound 3 lay 6.9 percentage points above the measured number; the range from low to high includes it.
By their numbers in this assay, from the lowest: compounds 3 and 2 (each within the scatter of the next); then compound 1.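

In this assay, 2-methoxyphenyl in place of 4-chlorophenyl on the amide-type nitrogen gives a number 3.5 percentage points lower from compound 2 to compound 3 (within the scatter) and thus no separation between these two aryl groups. (2-Methoxyphenyl)amino in place of ethoxy on the carbonyl carbon gives a number 15.4 percentage points lower from compound 1 to compound 3 (beyond the scatter), so a second arylamino group also stands apart from the ethyl ester. Nothing at hand accounts for either step. Still open, from the compounds shown here alone, is how an unsubstituted phenyl or a cyclohexyl group on the amide-type nitrogen would read. Going by these compounds, a free carboxylic acid in place of the ester is equally open.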